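The compounds below may be only part of what the source reports. "The series", "measured", "known", "first", "only" and "open" are said of these compounds alone.

Series notes. Going by the values given here, in an assay on isolated protein for inhibition of ubiquitin carboxyl-terminal hydrolase 7 (Homo sapiens), with stated times of 30 min and 2 h (on this read-out higher numbers stand for weaker inhibition and lower numbers for stronger inhibition), compound 3 `Cn1nc2c(=O)n(CC3(O)CCN(Cc4ccc(-c5ccco5)cc4Cl)CC3)cnc2c1-c1ccc(C(F)(F)F)cc1` gives 530 nM, the highest of the three numbers measured so far. Compound 1 `Cn1nc2c(=O)n(CC3(O)CCN(Cc4ccc(-c5ccco5)cc4Cl)CC3)cnc2c1-c1ccc(C2(N)CC2)cc1` gives 66.1 nM and compound 2 `Cn1nc2c(=O)n(CC3(O)CCN(Cc4ccc(-c5ccco5)cc4Cl)CC3)cnc2c1-c1ccc(CNCCO)cc1` gives 8.2 nM; the steps up to compound 3 are an 8.0-fold higher number from compound 1 to compound 3 (0.90 log units; beyond the scatter) and a 65-fold higher number from compound 2 to compound 3 (1.81 log units; beyond the scatter). Compound 4 `CCCNCc1ccc(-c2c3ncn(CC4(O)CCN(Cc5ccc(-c6ccco6)cc5Cl)CC4)c(=O)c3nn2C)cc1` differs from compound 3 by (propylamino)methyl in place of trifluoromethyl on an aromatic carbon. This change most closely resembles the reverse of the step that gave a 65-fold higher number from compound 2 to compound 3 (1.81 log units; beyond the scatter), since both entering groups are secondary-amine methyl groups; the step of an 8.0-fold higher number from compound 1 to compound 3 (0.90 log units; beyond the scatter) points the same way. For compound 4 a large fall in the number is therefore expected, a 44-fold lower number from compound 3 to compound 4 (1.65 log units; beyond the scatter). Compound 4 is expected to give 12 nM, with a range from 4 nM to 40 nM.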

Compound 4, half-maximal inhibitory concentration: 43.9 nM
Compound 4: the middle estimate sits 3.7-fold (0.56 log units) below what was measured; measured number outside the range, above it.
By their numbers in this assay, from the lowest: compound 2; then compounds 4 and 1 (each within the scatter of the next); then compound 3.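

In this assay, a 12-fold lower number from compound 3 to compound 4 (1.08 log units; beyond the scatter) shows that a simple alkyl secondary amine, (propylamino)methyl, also gives a far lower number than trifluoromethyl on this aromatic carbon. The chain end counts too: a 5.4-fold higher number from compound 2 to compound 4 (0.73 log units; beyond the scatter) goes with methyl in place of hydroxy, two bonds along the chain from the amine nitrogen. The exact amine group matters less in one case, as a 1.5-fold lower number from compound 1 to compound 4 (0.18 log units; within the scatter) leaves (propylamino)methyl level with 1-aminocyclopropyl.

From the compounds shown here alone, whether a tertiary amine, a longer chain or a carboxylic acid on this carbon would hold or lower the number stays open. Nothing available explains these differences.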